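The source may hold more compounds than are shown below. What is called first, only, known or untested is meant among the compounds shown, and "the series" means these compounds.

Measured so far:
- Compound 1, `Cc1sc(N)c(C(=O)c2cccs2)c1C`, in an assay on CHO-K1 cells with adenosine receptor A1 (Homo sapiens) as the target (a lower number here means that less compound is needed, a higher number that more compound is needed for the effect), compound 1 gives 11200 nM.
- Compound 2, `CCOC(=O)c1nn(-c2ccc(C(C)(C)C)cc2)c(=O)c2c(N)scc12`, in this assay compound 2 gives 9750 nM.
- Compound 3, `CCOC(=O)c1nn(-c2cccc(Cl)c2)c(=O)c2c(N)scc12`, in this assay compound 3 gives 5700 nM.

Compound 3 has the lowest of the three numbers, but its gap to compound 2 and its gap to compound 1 both fall within the usual scatter of the measurement, so the three values are best taken as standing close together rather than in any order.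

The step now followed leads from compound 3 to compound 4, `CCOC(=O)c1nn(-c2cccc(C(F)(F)F)c2)c(=O)c2c(N)scc12`, which has not yet been measured. The change is trifluoromethyl in place of chloro on an aromatic carbon. Among the measured compounds shown here, no step between measured compounds resembles this one, so there is nothing here to set its size from. The expectation is that the step from compound 3 to compound 4 stays within the scatter in this assay, with no clear direction; the estimated step is a 1.1-fold lower number from compound 3 to compound 4 (0.06 log units; within the scatter). Compound 4 is therefore expected to give about 5000 nM in this assay, within a range from 1500 nM to 16000 nM.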

Compound 4, half-maximal effective concentration: 2700 nM
Compound 4: middle estimate off by 1.9-fold (0.27 log units), on the high side; measured number inside the range.
By their numbers in this assay, from the lowest: compound 4; then compounds 3, 2 and 1 (each within the scatter of the next).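

In this assay, the swap of chloro for trifluoromethyl on an aromatic carbon gives a 2.1-fold lower number from compound 3 to compound 4 (0.32 log units; beyond the scatter), a modest step but one printed as beyond the scatter. Among the compounds shown here, the earlier compounds could not show this, as their values stood within the scatter of one another and no pair among them differed in one place, so this is the first sign that the group at this position can move the number, though it rests on a single pair. No measurement at hand gives a reason for this step.

From the compounds shown here alone, whether a nitrile, a methoxy group or a carboxylic acid at this position would continue in the same direction remains open. Going by these compounds, it is also open whether the same swap would give a similar step elsewhere on the ring or on the core of compound 1.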